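The source may hold more compounds than are shown below. What is called first, only, known or untested is meant among the compounds shown, and "the series" means these compounds.

In an assay on a protein complex for binding affinity to integrin alpha-4/beta-1 (Homo sapiens), read by scintillation proximity assay, with a stated time of 1 h (on this read-out lower numbers stand for stronger inhibition and higher numbers for weaker inhibition), two small carboxylic acids have been examined so far. Compound 1, `Cc1ccccc1C(=O)N1C(=O)C[C@H]1C(=O)O`, reaches only the limit of the method there, giving > 1000 nM. Compound 2, `Cc1ccccc1NC(=O)NCC(=O)O`, likewise gives > 1000 nM, a limit of this assay rather than a measured number. Compound 2 therefore stands at the limit of > 1000 nM in this assay, at which 2 of the 2 values shown sit, and on the numbers in hand nothing separates it from compound 1. Compound 3, `Cc1ccccc1NC(=O)NCCC(=O)O`, is the next member: its change from compound 2 is carboxymethyl in place of carboxy on a saturated chain carbon bound to an amide-type nitrogen; the same difference, cut one bond further out, reads carboxymethyl to 2-carboxyethyl. Within the data shown here, no step between measured compounds exists to gauge such a change, and with both known values resting at the limit, the expectation for this assay is no shift beyond the scatter, the result most likely coming back as a limit once more. Compound 3 is thus expected at about 3000 nM, within 800 nM to 20000 nM. That expectation amounts to a step that the limit leaves unreadable from compound 2 to compound 3 in this assay.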

Compound 3, half-maximal inhibitory concentration: > 1000 nM
Compound 3: a limit, no number; the forecaster's own chance of this, stated with the estimate: 85%; the middle value is on the limit's open side.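

Among these compounds, no step from compound 2 to compound 3 can be read in this assay, as both results are limits and not numbers: the limit of > 1000 nM in this assay, at which 3 of the 3 values shown sit. The compounds shown leave open where any of the three would fall as an actual number, and so whether the change from carboxymethyl to 2-carboxyethyl alters the read-out at all.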